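Methyl for trifluoromethyl on the fused core: cytotoxicity outlook

A few compounds are considered here, and "the series" means these few. Any claim that something is new, unique, unknown or untested is made for them only; others in the source may bear on it.

Among the compounds with values here, compound 2 `Fc1ccc(Nc2c(-c3ccccn3)nc3cc(C(F)(F)F)ccn23)cc1` gives 23700 nM in an ADME assay on THP-1 cells (Homo sapiens) for cytotoxicity (a lower number here means that less compound is tolerated, a higher number that more compound is tolerated), the only plain number in the set. Compound 1 `Cc1ccn2c(Nc3ccccn3)c(-c3ccccn3)nc2c1` sits at the limit of > 50000 nM in this assay, at which 1 of the 2 values shown sits, a limit of this assay rather than a number. Compound 3 `Cc1ccn2c(Nc3ccc(F)cc3)c(-c3ccccn3)nc2c1` is not yet measured; against compound 2 the change is methyl in place of trifluoromethyl on an aromatic carbon. Within the data shown here, no measured pair covers this change. The step of a 1.7-fold higher number from compound 2 to compound 3 (0.23 log units; within the scatter) is expected to be upward and modest, possibly within scatter, since compound 1 carrying the same methyl group reaches only the limit > 50000 nM. Compound 3 is estimated at 40000 nM, range 15000 nM to 60000 nM, with a fair chance that only a limit is reported.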

Compound 3, half-maximal cytotoxic concentration: 5900 nM
Beside the measured number, compound 3's estimate is 6.8-fold (0.83 log units) above it; the whole stated range lies above it.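

In this assay, within the data shown here, the only measured pair at this position, opposite the ring nitrogen, gives a 4.0-fold lower number from compound 2 to compound 3 (0.60 log units; beyond the scatter), so methyl in place of trifluoromethyl moves the number down, beyond the scatter. With methyl held constant, 4-fluorophenyl in place of pyridin-2-yl on a nitrogen on an aromatic ring gives an at least 8.4-fold lower number from compound 1 to compound 3 (0.92 log units; beyond the scatter), so that group also matters. For compound 1 the value is a limit of the assay and not a number: the limit of > 50000 nM in this assay, at which 1 of the 3 values shown sits.

From the compounds shown here alone, whether chlorine, methoxy or an amine at this position would fall nearer methyl or trifluoromethyl remains open. Also open, going by these compounds, is whether the 4-fluorophenyl step holds with trifluoromethyl on the core.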